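This account rests on a few compounds, and the source may have more. Where it says the series, first, only, none or still open, it means among the compounds named here.

In a functional assay on MCF7 cells (Homo sapiens) for antiproliferative activity, read by MTT assay, with a stated time of 48 h (a higher number here means a weaker inhibitor, a lower number a stronger inhibitor), three compounds have been measured:

Compound 1 `COc1cccc(C(=O)Nc2nnc(/C=C/c3cc(OC)c(OC)c(OC)c3Br)s2)c1`: 170 nM
Compound 2 `COc1cc(/C=C/c2nnc(NC(=O)c3cccc(O)c3)s2)c(Br)c(OC)c1OC`: 360 nM
Compound 3 `COc1cccc(C(=O)Nc2nnc(/C=C/c3cc(OC)c(OC)c(OC)c3)s2)c1`: 480 nM

Compound 3 stands within the usual scatter of compound 2. Hydrogen in place of bromo on an aromatic carbon gave a 2.8-fold higher number from compound 1 to compound 3 (0.45 log units; beyond the scatter).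

Compound 4 `COc1cc(/C=C/c2nnc(NC(=O)c3cccc(O)c3)s2)cc(OC)c1OC` differs from compound 3 in one place, where 3-methoxyphenyl becomes 3-hydroxyphenyl: hydrogen in place of methyl on an oxygen on an aromatic ring. The same exchange, hydrogen in place of methyl on an oxygen on an aromatic ring, has been measured once, with bromo present, and gave a 2.1-fold higher number from compound 1 to compound 2 (0.33 log units; beyond the scatter). That single precedent points to a modest rise in the number in this assay, so the expected change is a 2.0-fold higher number from compound 3 to compound 4 (0.30 log units; within the scatter). For compound 4 the estimated value is 950 nM, with an expected range of 450 nM to 2000 nM.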

Compound 4, half-maximal inhibitory concentration: 460 nM
Estimate against measurement, compound 4: 2.1-fold (0.31 log units) above; measured number inside the range.
By their numbers in this assay, from the lowest: compound 1; then compounds 2, 4 and 3 (each within the scatter of the next).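

Hydrogen in place of methyl on an oxygen on an aromatic ring, read without bromo, gave a 1.0-fold lower number from compound 3 to compound 4 (0.02 log units; within the scatter) in this assay, yet this cannot be told apart from the step seen with bromo present: the same change on two cores in this assay, a 2.1-fold higher number (0.33 log units; beyond the scatter) from compound 1 to compound 2 and a 1.0-fold lower number (0.02 log units; within the scatter) from compound 3 to compound 4, 2.2-fold (0.34 log units) apart, within the scatter of two such steps

Hydrogen in place of bromo on an aromatic carbon, read with 3-hydroxyphenyl, gave a 1.3-fold higher number from compound 2 to compound 4 (0.11 log units; within the scatter), and this too cannot be told apart from the step seen with 3-methoxyphenyl: the same change on two cores in this assay, a 2.8-fold higher number (0.45 log units; beyond the scatter) from compound 1 to compound 3 and a 1.3-fold higher number (0.11 log units; within the scatter) from compound 2 to compound 4, 2.2-fold (0.34 log units) apart, within the scatter of two such steps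

Each change now has a second reading, and these readings do not show either change depending on the other.

Going by these compounds, what an ethoxy group or an amine would do in place of the methoxy stays open, as does what chloro or fluoro would do in place of bromo.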